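This account rests on a few compounds, and the source may have more. Where it says the series, first, only, none or still open, it means among the compounds named here.

Measured compounds:

compound 1, `CCCCCCCCCCc1cc2cn(COCCO)c(O)nc-2n1` — 80000 nM
compound 2, `CCCCCCCCCc1cc2cn(COCCO)c(O)nc-2n1` — > 80000 nM
compound 3, `CCCCCc1cc2cn(COCCO)c(=O)nc2o1` — > 400000 nM

In a functional assay on HEL cells (Homo sapiens), read by microscopy (on this read-out higher numbers stand for lower toxicity in this test and lower numbers for higher toxicity in this test), compound 3 gives > 400000 nM, which is a limit of the assay and not a number. In this assay compound 2 likewise gives > 80000 nM, again a limit. Compound 1 gives 80000 nM in this assay. The change from compound 2 to compound 1 is methyl in place of hydrogen on a saturated chain carbon, nine bonds along the chain from an aromatic carbon; the step reads a number no higher from compound 2 to compound 1 (the limit leaves the size open), and its size is not readable because the limit of > 80000 nM in this assay, at which 1 of the 3 values shown sits, sits under it. The cores of compound 2 and compound 3 differ in more than one place; that difference is not broken down here.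

Compound 4, `CCCCCCc1cc2cn(COCCO)c(=O)nc2o1`, is not yet measured. Relative to compound 3 it carries methyl in place of hydrogen on a saturated chain carbon, five bonds along the chain from an aromatic carbon. This is the same kind of change as from compound 2 to compound 1, but not the same: there the methyl enters nine bonds along the chain from an aromatic carbon, here five bonds along the chain from an aromatic carbon.

For compound 4 in this assay a step of a number no higher from compound 3 to compound 4 (the limit leaves the size open) is expected, resting on the step from compound 2 to compound 1, whose size the limit of compound 2 leaves open, and on (the limit of > 400000 nM in this assay, at which 1 of the 3 values shown sits), at which compound 3 sits. Compound 4 is estimated at 400000 nM, with a range from 100000 nM to 800000 nM, and a further limit reading is considered the likelier outcome.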

Compound 4, minimum cytotoxic concentration: >= 400000 nM
Compound 4: only a limit was reported (the forecaster's own chance of this, stated with the estimate: 70%); the middle value lies on the limit itself.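

In this assay compound 3 gives > 400000 nM, a limit of the assay and not a number. Compound 4 gives >= 400000 nM, also a limit. No step can be read between compound 3 and compound 4. The compounds shown leave open whether methyl in place of hydrogen, five bonds along the chain from an aromatic carbon, changes the read-out at all on this core.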